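The source may hold more compounds than are shown below. What is called first, only, known or untested is meant among the compounds shown, and "the series" means these compounds.

Of the compounds shown here, two with a shared core have been measured in a functional assay on HeLa cells (Homo sapiens) for antiproliferative activity; a higher number here means a weaker inhibitor, a lower number a stronger inhibitor. Compound 1 `Nc1nc(Nc2ccc(S(=O)(=O)NC(=O)CCC(=O)O)cc2)nn1C(=O)c1c(F)cccc1F` gives 31900 nM. Compound 2 `NCC(=O)NS(=O)(=O)c1ccc(Nc2nc(N)n(C(=O)c3c(F)cccc3F)n2)cc1` gives 14900 nM. Going from one to the other, the carboxymethyl on a saturated chain carbon bound to a carbonyl carbon is replaced by amino, which gives a 2.1-fold lower number from compound 1 to compound 2 (0.33 log units; beyond the scatter). Among the measured compounds shown here, compound 2 thus holds the lower of the two numbers, with compound 1 the only neighbour for comparison.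

Compound 3 `COCCOCC(=O)NS(=O)(=O)c1ccc(Nc2nc(N)n(C(=O)c3c(F)cccc3F)n2)cc1` has not yet been measured. Its difference from compound 2 is 2-methoxyethoxy in place of amino on a saturated chain carbon bound to a carbonyl carbon. For the measured compounds named here, the only measured step touches this same place, but it swaps a different pair of groups, so it bears on the new change only loosely: it shows that alterations at this position have so far moved the number modestly, not by a large amount. The expected step from compound 2 is therefore small, a 1.3-fold higher number from compound 2 to compound 3 (0.13 log units; within the scatter), and could fall inside the scatter. Compound 3 is estimated to give 20000 nM in this assay, with a likely range from 7000 nM to 60000 nM.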

Compound 3, half-maximal inhibitory concentration: > 10000 nM
Compound 3: no number, only a limit; the forecaster's own chance of this, stated with the estimate: 10%; the middle value does not contradict the limit.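

In this assay compound 3 gives > 10000 nM, which is a limit of the assay and not a number. The steps to compound 3 from compound 1 and from compound 2 cannot be read. Open, going by these compounds, is whether 2-methoxyethoxy in place of amino raises the number, lowers it or leaves it within the usual scatter.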